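A few compounds are considered here, and "the series" means these few. Any claim that something is new, unique, unknown or untested is made for them only; others in the source may bear on it.

Working notes on a short series tested in a functional assay on A549 cells (Homo sapiens) for cytotoxicity, read by sulforhodamine B assay; a higher number here means a weaker inhibitor, a lower number a stronger inhibitor. Compound 1 `CCCCN1C(=O)c2cccc3c2c(cc2c4ccccc4sc32)C1=O` gives 1350 nM in this assay. Compound 2 `CCCCN1C(=O)c2cccc3c2c(cc2c4ccccc4oc32)C1=O` gives 1400 nM in this assay; the difference between the two cores is not broken down here, and the two values show no separation of note. Compound 3 `CN(C)CCCN1C(=O)c2cccc3c2c(cc2c4ccccc4oc32)C1=O` gives 740 nM in this assay. The change from compound 2 to compound 3 is dimethylamino in place of methyl on a saturated chain carbon, three bonds along the chain from an amide-type nitrogen in a ring and made a 1.9-fold lower number from compound 2 to compound 3 (0.28 log units; within the scatter).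

Compound 4 `CN(C)CCCN1C(=O)c2cccc3c2c(cc2c4ccccc4sc32)C1=O` has not yet been measured in this assay. It stands to compound 1 as compound 3 stands to compound 2: the change is dimethylamino in place of methyl on a saturated chain carbon, three bonds along the chain from an amide-type nitrogen in a ring, the same change carried onto the core of compound 1 instead of the core of compound 2. Going by the values given here, only one measured instance of this change exists, so the expectation for compound 4 rests on it alone. Among the compounds with values here, for compound 4 the expected step is a 1.9-fold lower number from compound 1 to compound 4 (0.27 log units; within the scatter), because the single measured instance gave a 1.9-fold lower number from compound 2 to compound 3 (0.28 log units; within the scatter). Compound 4 is accordingly expected to give 720 nM in this assay, with a plausible range from 350 nM to 1500 nM.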

Compound 4, half-maximal inhibitory concentration: 250 nM
The estimate for compound 4 lay 2.9-fold (0.46 log units) above the measured number; measured number below the stated range.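

Replacing butyl by 3-(dimethylamino)propyl gives a 5.4-fold lower number from compound 1 to compound 4 (0.73 log units; beyond the scatter) in this assay, so on this core the change registers clearly. The same change therefore does not carry over from one core to the other with the same size: the same change on two cores in this assay, a 1.9-fold lower number (0.28 log units; within the scatter) from compound 2 to compound 3 and a 5.4-fold lower number (0.73 log units; beyond the scatter) from compound 1 to compound 4, 2.9-fold (0.46 log units) apart, beyond the scatter of two such steps

This shows that, for these two cores, the size of the step cannot be read across from one to the other; it rests on a single pair of steps, so it gives neither a reason for the gap nor a rule for any further core.

The compounds shown leave open whether the gap between the two cores persists with a different amine, such as pyrrolidine or morpholine, in place of dimethylamino, or with a longer chain carrying the dimethylamino group. They also leave open whether a neutral group such as a hydroxyl at the end of the chain would give a step closer to either of the two seen here.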